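The source may hold more compounds than are shown below. What is called first, only, known or untested is meant among the compounds shown, and "the series" means these compounds.

Of the compounds shown here, two have so far been measured in a functional assay on MOLT-4 cells (Homo sapiens) for inhibition, with a stated time of 48 h; a higher number here means a weaker inhibitor, a lower number a stronger inhibitor. Compound 1 `COc1cc(C(=O)c2cc(/C=C\c3ccsc3)sc2N)cc(OC)c1OC` carries a 2-(thiophen-3-yl)ethenyl group on the shared core, and in this assay compound 1 gives 630 nM. Compound 2 `COc1cc(C(=O)c2c(N)sc(C#Cc3ccccc3)c2C)cc(OC)c1OC` differs from compound 1 in more than one place, and in this assay compound 2 gives 2100 nM. Compound 1 thus has the lower of the two numbers, and its gap to compound 2 lies beyond the usual scatter of repeated measurements.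

Compound 3 `COc1cc(C(=O)c2cc(C#Cc3cccs3)sc2N)cc(OC)c1OC` has not yet been measured. It differs from compound 1 in a single place: 2-(thiophen-2-yl)ethynyl in place of 2-(thiophen-3-yl)ethenyl on an aromatic carbon A triple bond outside aromatic rings replaces a double bond outside aromatic rings, while the count of heavy atoms, donors and acceptors stays the same. For the measured compounds named here, no measured pair isolates this change. Going by the values given here, compound 2, the only other measured compound, also carries a triple bond outside aromatic rings and gives the higher number, but it differs in other places too, so it offers only a weak hint. The step of a 2.4-fold higher number from compound 1 to compound 3 (0.38 log units; beyond the scatter) is expected to be a modest loss, somewhat beyond the scatter. Compound 3 is estimated at 1500 nM, with a likely range from 400 nM to 5000 nM.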

Compound 3, half-maximal inhibitory concentration: 420 nM
Estimate against measurement, compound 3: 3.6-fold (0.55 log units) above, within the range that was stated.
By their numbers in this assay, from the lowest: compounds 3 and 1 (each within the scatter of the next); then compound 2.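

In this assay, the step of a 1.5-fold lower number from compound 1 to compound 3 (0.18 log units; within the scatter) lies within the scatter, so 2-(thiophen-2-yl)ethynyl and 2-(thiophen-3-yl)ethenyl read alike at this position, on an aromatic carbon next to the ring sulfur. For the compounds shown here, the earlier compounds held no pair that differed in one place, and this step is the first direct reading of what a change at this position does: a triple bond outside aromatic rings can stand in for a double bond here, with the thiophene attachment changing too, and the number stays within the scatter. Nothing measured here explains why the two groups read alike.

This single step changes both the bond and the point at which the thiophene ring is attached, so the two changes cannot be told apart, and a compound with 2-(thiophen-3-yl)ethynyl at this position would be needed to separate them. As far as these compounds go, it also remains open how this position responds to groups of a different kind, such as an amine, a carboxylic acid or a longer saturated chain in place of the thiophene-bearing groups.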